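Swapping Fluoro for Ethynyl on a Rapidly Cleared Compound

The source may report more compounds than this note shows. Statements on the series, on what has been measured and on what is new or still open speak of the compounds shown alone.

For the measured compounds named here, in an ADME assay on microsomes from liver (Homo sapiens) for metabolic stability, read by LC-MS, using NADPH, with a stated time of 10 min, tested at 0.1 uM (on this read-out lower numbers stand for slow clearance and higher numbers for fast clearance), compound 3 `COc1ccccc1N1C(=O)CSC1c1cc(F)cc(C(=O)NCCCCc2ccccc2)c1` gives 2080 mL.min-1.g-1 and so sits at the fast end of the numbers measured so far. Compound 1 `CC1SC(c2cccc(C(=O)NCCCCc3ccccc3)c2)N(c2ccc(C3CC3)cc2)C1=O` gives 2010 mL.min-1.g-1 which is within the usual scatter of compound 3, while compound 2 `COc1ccc(F)cc1N1C(=O)CSC1c1cccc(C(=O)NCCCCn2cccn2)c1` gives 421 mL.min-1.g-1 as a number clearly lower than both. Compound 4 `C#Cc1cc(C(=O)NCCCCc2ccccc2)cc(C2SCC(=O)N2c2ccccc2OC)c1` differs from compound 3 by a single change ethynyl in place of fluoro on an aromatic carbon with ethynyl in place of fluoro on an aromatic carbon. Going by the values given here, no measured pair shows what such a change does, so no step beyond the scatter is expected in this assay here. The estimated step of a 1.0-fold lower number from compound 3 to compound 4 (0.02 log units; within the scatter) is therefore small. For compound 4 the estimate is 2000 mL.min-1.g-1 with an expected range from 1000 mL.min-1.g-1 to 4000 mL.min-1.g-1 as the likely span.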

Compound 4, intrinsic clearance in microsomes in the Homo sapiens assay: 1730 mL.min-1.g-1
Estimate against measurement, compound 4: 1.2-fold (0.06 log units) above, within the range that was stated.
By their numbers in the Homo sapiens assay, from the lowest: compound 2; then compounds 4, 1 and 3 (each within the scatter of the next).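

For the compounds shown here, compound 3 and compound 4 are the first measured pair that differ in one place only, and in the Homo sapiens assay ethynyl in place of fluoro on this aromatic carbon gives a 1.2-fold lower number from compound 3 to compound 4 (0.08 log units; within the scatter) and leaves clearance at the fast end of the numbers. In the Homo sapiens assay compound 3 gives 2080 mL.min-1.g-1 and compound 4 gives 1730 mL.min-1.g-1. In a physicochemical assay for solubility, read by turbidimetry, measured as kinetic solubility, at pH 7.4 (a lower number here means a less soluble compound, a higher number a more soluble compound), the same change gives no change at the digits printed from compound 3 to compound 4 (within the scatter) and so leaves solubility as it was. In the physicochemical assay compound 3 gives 10000 nM and compound 4 gives 10000 nM. Nothing available here speaks to why the two groups read alike. Only fluoro and ethynyl have been seen at this position, so an amine or a carboxylic acid on the same carbon remains an open question. As far as these compounds go, whether this swap would read the same on another core is also open.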